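The source may report more compounds than this note shows. Statements on the series, on what has been measured and on what is new or still open speak of the compounds shown alone.

Measured set in an ADME assay on HepG2 2.2.15 cells (Homo sapiens) for cytotoxicity; on this read-out higher numbers stand for lower toxicity in this test and lower numbers for higher toxicity in this test:
compound 1 `O=C(OCCc1c(-c2ccccc2Cl)c2cc(Cl)ccc2[nH]c1=O)C1CCCCC1` gives 38000 nM;
compound 2 `O=C(OCCc1c(-c2ccccc2Cl)c2cc(Cl)ccc2[nH]c1=O)c1ccc([N+](=O)[O-])cc1` gives 1600000 nM;
compound 3 `O=C(COc1ccccc1)OCCc1c(-c2ccccc2Cl)c2cc(Cl)ccc2[nH]c1=O` gives 81000 nM.

Compound 3 stands second highest of the three numbers. Its nearest neighbour is compound 1, with a 2.1-fold higher number from compound 1 to compound 3 (0.33 log units; beyond the scatter), and its furthest is compound 2, with a 20-fold lower number from compound 2 to compound 3 (1.30 log units; beyond the scatter). The only place that varies across the set is the substituent on the carbonyl carbon of the ester; the 4-nitrophenyl of compound 2 sets the number far above the other two, while cyclohexyl and phenoxymethyl lie close to each other.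

Compound 4 `C/C=C/C=C/C(=O)OCCc1c(-c2ccccc2Cl)c2cc(Cl)ccc2[nH]c1=O` differs from compound 3 by penta-1,3-dien-1-yl in place of phenoxymethyl on a carbonyl carbon.

All three measured steps bear on this position. Two of them, a 42-fold higher number from compound 1 to compound 2 (1.62 log units; beyond the scatter) and a 20-fold lower number from compound 2 to compound 3 (1.30 log units; beyond the scatter), were large and both involve the 4-nitrophenyl compound; the third, a 2.1-fold higher number from compound 1 to compound 3 (0.33 log units; beyond the scatter), was modest. Among the measured compounds shown here, none of the measured substituents is an open chain with two double bonds, so no direct analogue exists. The expected step in this assay is therefore modest and downward, toward the number of compound 1, 38000 nM, with no confident direction beyond that.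

Compound 4 is therefore estimated at 50000 nM, within 15000 nM to 200000 nM, which means an expected step of a 1.6-fold lower number from compound 3 to compound 4 (0.21 log units; within the scatter).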

Compound 4, half-maximal cytotoxic concentration: 440000 nM
Compound 4: the middle estimate sits 8.8-fold (0.94 log units) below what was measured; the whole stated range lies below it.
By their numbers in this assay, from the lowest: compound 1; then compound 3; then compound 4; then compound 2.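

In this assay, penta-1,3-dien-1-yl on the carbonyl carbon gives a 5.4-fold higher number from compound 3 to compound 4 (0.73 log units; beyond the scatter) and a 12-fold higher number from compound 1 to compound 4 (1.06 log units; beyond the scatter), so a high number at this position is not confined to the 4-nitrophenyl ester and is also reached by a substituent with no ring. Compound 2 still keeps the highest number, with a 3.6-fold lower number from compound 2 to compound 4 (0.56 log units; beyond the scatter), which places compound 4 inside the series, with ring-bearing substituents on both sides of it; among these four compounds, having a ring or not does not sort the numbers. Nothing measured in this set accounts for these differences.

The compounds shown leave open whether the step belongs to the two double bonds or simply to the open chain, a question a saturated pentyl group on the carbonyl carbon would separate. Also open, from the compounds shown here alone, is whether the number of compound 2 depends on the nitro group or on the phenyl ring alone, which an unsubstituted phenyl would test, and how a chain ending in an amine or a carboxylic acid would read in this assay.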